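The source may hold more compounds than are shown below. What is called first, only, known or untested is meant among the compounds shown, and "the series" means these compounds.

Measured compounds:
Compound 1 `O=C1C=CC(=O)N1c1cc(C(F)(F)F)cc(C(F)(F)F)c1` gives < 0.017 h in an ADME assay for pharmacokinetics, read by LC-MS, in phosphate buffer, with a stated time of 72 h, at pH 7.4, tested at 250 uM (on this read-out higher numbers stand for a longer-lived compound and lower numbers for a shorter-lived compound), which is a limit of the assay and not a number.
Compound 2 `O=C(CBr)c1cc(C(F)(F)F)cc(C(F)(F)F)c1` gives < 0.017 h in this assay, again a limit of the assay.

Compound 2 therefore stands at the limit, with no number of its own. Within the data shown here, the one recorded step, a step that the two limits leave unreadable from compound 1 to compound 2, cannot be read, since both of its ends sit at the limit of < 0.017 h in this assay, at which 2 of the 2 values shown sit. Among the measured compounds shown here, the only further value shown, that of compound 1, is also a limit.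

Compound 3 `Fc1cc(C(F)(F)F)cc(C(F)(F)F)c1` differs from compound 2 by fluoro in place of (bromomethyl)carbonyl on an aromatic carbon. For the measured compounds named here, no measured step bears on this change, and the single step on record is unreadable, so its size in this assay is not anchored by any measurement. The step expected is an at least 17000-fold higher number from compound 2 to compound 3 (4.24 log units; beyond the scatter), in the direction of a longer-lived compound and well beyond the scatter. Compound 3 is accordingly estimated at 300 h, with a range of 30 h to 3000 h, and the assay may report only a limit.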

Compound 3, half-life: > 50 h
Compound 3: no number, only a limit; the forecaster's own chance of this, stated with the estimate: 80%; the middle value lies beyond the limit too.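

Until now this aromatic carbon had given no readable step, and the new result supplies one: fluoro in place of (bromomethyl)carbonyl gives an at least 2900-fold higher number from compound 2 to compound 3 (3.46 log units; beyond the scatter). The one fluorine atom in place of the group of compound 1 gives an at least 2900-fold higher number from compound 1 to compound 3 (3.46 log units; beyond the scatter), so the half-life in this assay clearly depends on the group at this position, and both groups that sat at the low end part from fluoro by a large step. Compound 3 itself sits at a limit of the assay, which is not a number: the limit of > 50 h in this assay, at which 1 of the 3 values shown sits.

As far as these compounds go, the true half-lives of compound 1, compound 2 and compound 3 stay unknown, and with them the full size of both steps. Also open, from the compounds shown here alone, is where an amine, a carboxylic acid or a methoxy group on this aromatic carbon would fall between these two ends.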